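A few compounds are considered here, and "the series" means these few. Any claim that something is new, unique, unknown or untested is made for them only; others in the source may bear on it.

In a functional assay on KYSE-410 cells (Homo sapiens) for antiproliferative activity, read by MTT assay, with a stated time of 72 h (on this read-out higher numbers stand for weaker inhibition and lower numbers for stronger inhibition), compound 2 `O=C(Nc1cc(F)cc(F)c1)c1cc(=O)[nH]c2cc(F)ccc12` gives > 20000 nM, which is a limit of the assay and not a number. Its position on the numbers shown is therefore open on one side, and the data stand with the limit of > 20000 nM in this assay, at which 1 of the 2 values shown sits. Among the compounds with values here, the one measured neighbour is compound 1 `O=C(Nc1cc(F)cc(F)c1)c1cc(=O)[nH]c2cc(Br)ccc12`, which gives 11200 nM in this assay. Compound 3 `O=C(Nc1cc(F)cc(F)c1)c1cc(=O)[nH]c2cc(Cl)ccc12` differs from compound 2 by chloro in place of fluoro on an aromatic carbon. Within the data shown here, the only measured step that bears on this change is fluoro in place of bromo at the same place, an at least 1.7-fold higher number from compound 1 to compound 2 (0.25 log units; that floor lies within the scatter). That step is a small one on the evidence available, and it runs from bromo to fluoro, so chloro is expected to move the number modestly downward, if beyond the scatter at all. With bromo, compound 1 reaches 11200 nM, and that value is taken as the expected lower region for compound 3. The expected change is an at least 1.3-fold lower number from compound 2 to compound 3 (0.12 log units; that floor lies within the scatter). For compound 3 the estimate is 15000 nM, with an expected range from 7000 nM to 28000 nM.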

Compound 3, half-maximal inhibitory concentration: 11000 nM
Beside the measured number, compound 3's estimate is 1.4-fold (0.13 log units) above it, and the stated range covers the measured number.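

In this assay, the new compound shows that bromo is not alone at this place on the shared core: with chloro in place of bromo, the result is a 1.0-fold lower number from compound 1 to compound 3 (0.01 log units; within the scatter), so the two groups cannot be told apart on this read-out. With chloro in place of fluoro, the result is an at least 1.8-fold lower number from compound 2 to compound 3 (0.25 log units; that floor lies within the scatter), which gives this position a second step leaving fluoro, and it has the same size and direction as the step between compound 1 and compound 2, read in reverse. From the compounds shown here alone, the value of compound 2 is a limit of the assay and not a number, so the distance from fluoro to either of the other two groups stays open on one side: the limit of > 20000 nM in this assay, at which 1 of the 3 values shown sits.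

The compounds shown leave open whether any group on this aromatic carbon would move the number beyond the scatter of what chloro and bromo give, for instance a methoxy group, an amine or a carboxylic acid. They also leave open whether the likeness of chloro and bromo would hold with a change elsewhere on the shared core.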